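The compounds below may be only part of what the source reports. "The series", "measured", "known", "first", "only" and "open" are said of these compounds alone.

For the measured compounds named here, in a functional assay on HeLa cells (Homo sapiens) for antiproliferative activity, read by MTT assay, with a stated time of 48 h (a higher number here means a weaker inhibitor, a lower number a stronger inhibitor), only two compounds have numbers so far. Compound 1 `COc1ccc(C(=O)c2ccc(OC)c3c2OC(C)(C)C=C3)c(NC(=O)CBr)c1` stands higher at 2140 nM and is the weaker of the pair, while compound 2 `COc1ccc(C(=O)c2ccc3c(c2)C=CC(C)(C)O3)c(NC(=O)CO)c1` reads 240 nM and the gap lies beyond the usual scatter. Going by the values given here, no measured pair differs in one place only, so no measured step guides the next compound directly. Compound 3 `CCNCC(=O)Nc1cc(OC)ccc1C(=O)c1ccc(OC)c2c1OC(C)(C)C=C2` comes from compound 1 by a single change, ethylamino in place of bromo on a saturated chain carbon bound to a carbonyl carbon with ethylamino in place of bromo on a saturated chain carbon bound to a carbonyl carbon. With nothing measured for this change, in this assay no step beyond the scatter is expected, and any drift is thought more likely toward lower numbers. The estimated move is a 1.4-fold lower number from compound 1 to compound 3 (0.15 log units; within the scatter) and remains modest. Compound 3 is expected at 1500 nM within an estimated range of 350 nM to 6000 nM when measured.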

Compound 3, half-maximal inhibitory concentration: 2690 nM
The estimate for compound 3 lay 1.8-fold (0.25 log units) below the measured number; the range from low to high includes it.
By their numbers in this assay, from the lowest: compound 2; then compounds 1 and 3 (each within the scatter of the next).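

In this assay, for the compounds shown here, ethylamino in place of bromo on a saturated chain carbon bound to a carbonyl carbon gives a 1.3-fold higher number from compound 1 to compound 3 (0.10 log units; within the scatter), the first step that changes one place only. At this position on the core of compound 1, bromo, with 1 heavy atom and no hydrogen-bond donor, and ethylamino, with 3 heavy atoms and a hydrogen-bond donor and acceptor, cannot be told apart in this read-out. No measured evidence is at hand to explain this result. Compound 2 differs from compound 1 in more than one place and does not show what a hydroxy group at this carbon would do on the core of compound 1. As far as these compounds go, how a carboxylic acid, a morpholine ring or a longer amine chain would read here also remains open in this assay.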